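Swapping in 2-Chlorophenyl: A Step Hidden Behind Limits

The compounds below may be only part of what the source reports. "The series", "measured", "known", "first", "only" and "open" are said of these compounds alone.

In a physicochemical assay for solubility, measured as kinetic solubility (on this read-out lower numbers stand for lower solubility and higher numbers for higher solubility), compound 3 (`CNC(=O)c1cc(C(=O)N[C@H]2CC[C@H](O)CC2)n([C@@H](C)c2ccc(C(F)(F)F)cc2)n1`) gives >= 175 ug/mL, which is a limit and not a number. Compound 1 (`CNC(=O)c1cc(C(=O)N[C@H]2CC[C@H](O)CC2)n([C@@H](C)c2ccc(Cl)cc2)n1`) gives >= 132 ug/mL, also a limit. Compound 2 (`CNC(=O)c1cc(C(=O)N[C@H]2CC[C@H](O)CC2)n([C@@H](C)c2cccc(Cl)c2)n1`) gives >= 143 ug/mL, again a limit. Compound 3 therefore holds no readable rank among the three.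

Compound 4 (`CNC(=O)c1cc(C(=O)N[C@H]2CC[C@H](O)CC2)n([C@@H](C)c2ccccc2Cl)n1`) has 2-chlorophenyl in place of 4-(trifluoromethyl)phenyl on a saturated chain carbon bound to an aromatic nitrogen and a saturated chain carbon.

The closest evidence is a step that the two limits leave unreadable from compound 2 to compound 3. The same holds for a step that the two limits leave unreadable from compound 1 to compound 3 and for a step that the two limits leave unreadable from compound 1 to compound 2. None of these steps has a size, so the expectation rests only on all three compounds reporting limits in this assay. No step beyond the usual scatter is expected, and the estimate is an at least 1.1-fold lower number from compound 3 to compound 4 (0.06 log units; that floor lies within the scatter). Compound 4 is also expected to report a limit rather than a number. For compound 4 the estimate is 150 ug/mL, with an expected range from 100 ug/mL to 220 ug/mL.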

Compound 4, solubility: >= 182 ug/mL
Compound 4 was reported as a limit; the forecaster's own chance of this, stated with the estimate: 85%; middle value at least 1.2-fold (0.08 log units) from the limit.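

In this assay compound 4 gives >= 182 ug/mL, which is a limit and not a number. The steps to compound 4 from compound 1, compound 2 and compound 3 cannot be read. The compounds shown leave open whether these group swaps change this assay at all, and in which direction.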